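Ethoxy for methoxy on the benzyl ring

A few compounds are considered here, and "the series" means these few. Any claim that something is new, unique, unknown or untested is made for them only; others in the source may bear on it.

Compound 1 `COc1cccc(OC)c1OCCNCCOc1ccccc1OCc1ccccc1C`: 33900 nM
Compound 2 `COc1ccccc1COc1ccccc1OCCNCCOc1c(OC)cccc1OC`: 30200 nM
Compound 3 `COc1cccc(COc2ccccc2OCCNCCOc2c(OC)cccc2OC)c1`: 15100 nM

In a functional assay on PC-3 cells (Homo sapiens) for cytotoxicity, read by sulforhodamine B assay (on this read-out higher numbers stand for weaker inhibition of growth and lower numbers for stronger inhibition of growth), compound 3 gives the lowest of the three numbers, though compound 2 sits within the scatter of it. Compound 4 `CCOc1ccc(COc2ccccc2OCCNCCOc2c(OC)cccc2OC)cc1` differs from compound 3 only in that (4-ethoxyphenyl in place of 3-methoxyphenyl on a saturated chain carbon bound to an oxygen on an aromatic ring). Two measured steps also change this same group: a 2.2-fold lower number from compound 1 to compound 3 (0.35 log units; beyond the scatter), and a 2.0-fold lower number from compound 2 to compound 3 (0.30 log units; within the scatter). Both are small, one within the scatter and one only just beyond it, so swapping one such group for another has so far moved the numbers little. Compound 4 is therefore expected to give a number close to that of compound 3, with no step beyond the scatter, namely a 1.0-fold lower number from compound 3 to compound 4 (0.00 log units; within the scatter). The estimate for compound 4 in this assay is 15000 nM, between 6000 nM and 40000 nM.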

Compound 4, concentration for total growth inhibition: 18200 nM
The estimate for compound 4 lay 1.2-fold (0.08 log units) below the measured number; the range from low to high includes it.
By their numbers in this assay, from the lowest: compounds 3, 4, 2 and 1 (each within the scatter of the next, the first and the last beyond it).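

In this assay, 4-ethoxyphenyl on this saturated chain carbon stays within the scatter of all three earlier groups: (a 1.2-fold higher number from compound 3 to compound 4 (0.08 log units; within the scatter)), (a 1.7-fold lower number from compound 2 to compound 4 (0.22 log units; within the scatter)) and (a 1.9-fold lower number from compound 1 to compound 4 (0.27 log units; within the scatter)). This position therefore accepts an ethoxy group on the ring without a change that can be told from the scatter. Nothing at hand gives a reason for this.

Since the step from compound 3 to compound 4 changes both the group and its ring position, 4-methoxyphenyl or 3-ethoxyphenyl would be needed to separate the two. As far as these compounds go, whether a ring bearing an amine or a carboxylic acid would behave the same also stays open.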